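Amide chain trimming on the pyrazolyl-substituted core

This account rests on a few compounds, and the source may have more. Where it says the series, first, only, none or still open, it means among the compounds named here.

Measured so far:
compound 1 `CCC1C(=O)N(C)c2cnc(-n3ccc4cc(C(=O)NCC(C)C)ccc43)nc2N1c1ccn(C)n1` gives 10200 nM
compound 2 `CC[C@@H]1C(=O)N(C)c2cnc(-n3ccc4cc(C(=O)NCC(C)C)ccc43)nc2N1C1CCCC1` gives "not active" (no number reported)
compound 3 `CCCNC(=O)c1ccc2c(ccn2-c2ncc3c(n2)N(C2CCCC2)[C@H](CC)C(=O)N3C)c1` gives 786 nM

In a functional assay on NCI-H1975 cells (Homo sapiens) for antiproliferative activity, read by CCK-8 assay, with a stated time of 72 h (on this read-out higher numbers stand for weaker inhibition of growth and lower numbers for stronger inhibition of growth), compound 1 holds the highest of the two reported numbers; compound 3 sits well lower, a gap beyond the scatter, and compound 2 is reported without a number. Going by the values given here, compounds 2 and 3 differ in more than one place, so their values show only that the pair spans from inactive to the best number here.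

Compound 4 `CCCNC(=O)c1ccc2c(ccn2-c2ncc3c(n2)N(c2ccn(C)n2)C(CC)C(=O)N3C)c1` differs from compound 1 by hydrogen in place of methyl on a saturated chain carbon bound to two saturated chain carbons. Among the compounds with values here, no measured pair isolates this change. The step from compound 1 to compound 4 is expected to be small, toward stronger inhibition, and probably within the scatter: a 1.7-fold lower number from compound 1 to compound 4 (0.23 log units; within the scatter). Compound 4 is estimated at 6000 nM, within 2000 nM to 20000 nM.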

Compound 4, concentration for 50% growth inhibition: 11000 nM
Compound 4: middle estimate off by 1.8-fold (0.26 log units), on the low side; low and high end bracket the measured number.
By their numbers in this assay, from the lowest: compound 3; then compounds 1 and 4 (each within the scatter of the next).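

Going by these compounds alone, the first pair to isolate isobutyl to propyl on the amide gives, in this assay, a 1.1-fold higher number from compound 1 to compound 4 (0.03 log units; within the scatter). On this core, therefore, the two chains cannot be told apart, and compounds 1 and 4 sit within the scatter of each other. Nothing available accounts for this result.

From the compounds shown here alone, whether the same equivalence holds on a core carrying another group in place of the methylpyrazolyl remains open. Also open, going by these compounds, is how a longer chain, or a chain ending in an amine or a carboxylic acid, would read on the amide.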